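The compounds below may be only part of what the source reports. "The series", "measured", "known", "first", "only" and "open" are said of these compounds alone.

Working notes on the series, read in a functional assay on HeLa cells (Homo sapiens) for cytotoxicity, read by MTT assay, with a stated time of 48 h; on this read-out lower numbers stand for stronger inhibition and higher numbers for weaker inhibition. Compound 3 (`COc1cc(N/C=C\C(=O)c2c(-c3ccc(Cl)cc3)nc3ccccn23)cc(OC)c1`) gives 14600 nM and compound 1 (`COc1ccc(-c2nc3ccccn3c2C(=O)/C=C\Nc2ccc3[nH]ccc3c2)cc1`) gives 13600 nM, two values within the scatter of each other. Compound 2 (`COc1cc(N/C=C\C(=O)c2c(-c3ccc(Cl)cc3)nc3ccccn23)cc(OC)c1OC`) gives 3020 nM. Among the compounds with values here, the only measured single-site step, a 4.8-fold higher number from compound 2 to compound 3 (0.68 log units; beyond the scatter), is modest but beyond the scatter, so the group on the amine nitrogen can move the number.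

The next compound is compound 4 (`O=C(/C=C\Nc1ccc2[nH]ccc2c1)c1c(-c2ccc(Cl)cc2)nc2ccccn12`), which differs from compound 3 as follows: 1H-indol-5-yl in place of 3,5-dimethoxyphenyl on an amine nitrogen. Within the data shown here, no measured step isolates this replacement of 3,5-dimethoxyphenyl by 1H-indol-5-yl. The closest evidence is compound 1, which carries the same 1H-indol-5-yl on the amine nitrogen and gives 13600 nM, although it differs from compound 4 elsewhere. That value suggests no large gain from the indolyl group, while the modest step measured above leaves room for movement in either direction. No shift beyond the scatter is therefore expected in this assay.

The estimated step is a 1.5-fold lower number from compound 3 to compound 4 (0.16 log units; within the scatter). For compound 4 the estimated value is 10000 nM, with an expected range of 4000 nM to 28000 nM.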

Compound 4, half-maximal inhibitory concentration: 3240 nM
The estimate for compound 4 lay 3.1-fold (0.49 log units) above the measured number; measured number outside the range, below it.
By their numbers in this assay, from the lowest: compounds 2 and 4 (each within the scatter of the next); then compounds 1 and 3 (each within the scatter of the next).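

In this assay, 1H-indol-5-yl in place of 3,5-dimethoxyphenyl on the amine nitrogen gives a 4.5-fold lower number from compound 3 to compound 4 (0.65 log units; beyond the scatter), so replacing the whole aryl group moves the number as well as removing one methoxy does, and compound 2 at 3020 nM and compound 4 at 3240 nM lie within the scatter of each other. With 1H-indol-5-yl held fixed, chloro in place of methoxy on an aromatic carbon gives a 4.2-fold lower number from compound 1 to compound 4 (0.62 log units; beyond the scatter), which shows that the second site also moves the number and that the value of compound 1 alone did not describe what the indolyl group does in the chloro compounds. Nothing available explains either step.

The compounds shown leave open whether the two sites act independently, as no compound pairs the methoxy on that aromatic carbon with 3,5-dimethoxyphenyl on the amine nitrogen. From the compounds shown here alone, it also remains open whether fluoro or trifluoromethyl can stand in place of chloro, and whether a 1-methylindol-5-yl or a benzimidazolyl group on the amine nitrogen would keep the number of compound 4.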